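The source may report more compounds than this note shows. Statements on the series, on what has been measured and on what is new or still open speak of the compounds shown alone.

In a functional assay on cells (leukaemia cell line, Homo sapiens) for inhibition, read by sulforhodamine B assay, with a stated time of 48 h (on this read-out lower numbers stand for stronger inhibition of growth and higher numbers for weaker inhibition of growth), compound 1 `O=S(=O)(Nc1ccc(Cl)cc1Cl)c1ccc(-c2cnc(C3CC3)o2)cc1` gives 74500 nM while compound 2 `O=S(=O)(Nc1cccc(Cl)c1)c1ccc(-c2cnc(C3CC3)o2)cc1` gives 54200 nM and compound 3 `O=S(=O)(Nc1ccc(F)cc1F)c1ccc(-c2cnc(C3CC3)o2)cc1` gives 66100 nM on the same core. Compound 2 stands within the scatter of both others, so these numbers do not rank the three. Compound 4 `O=S(=O)(Nc1cc(Cl)ccc1Cl)c1ccc(-c2cnc(C3CC3)o2)cc1` differs from compound 2 by the change chloro in place of hydrogen on an aromatic carbon with chloro in place of hydrogen on an aromatic carbon, which turns 3-chlorophenyl to 2,5-dichlorophenyl. Going by the values given here, the steps that bear on it are a 1.4-fold lower number from compound 1 to compound 2 (0.14 log units; within the scatter) and a 1.1-fold lower number from compound 1 to compound 3 (0.05 log units; within the scatter) and a 1.2-fold higher number from compound 2 to compound 3 (0.09 log units; within the scatter) on that same sulfonamide nitrogen. All stayed within the scatter, so no step beyond the scatter is expected in this assay and no direction is favoured. The expected change is a 1.1-fold higher number from compound 2 to compound 4 (0.06 log units; within the scatter) in this estimate. Compound 4 is estimated at 62000 nM with an expected range from 36000 nM to 100000 nM in this measurement.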

Compound 4, concentration for total growth inhibition: > 100000 nM
Compound 4 ended at the assay's limit; the forecaster's own chance of this, stated with the estimate: 12%; at least 1.6-fold (0.20 log units) between middle value and limit.
By their numbers in this assay, from the lowest: compounds 2, 3 and 1 (each within the scatter of the next). At a limit, above all of these: compound 4.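

In this assay compound 4 gives > 100000 nM, which is a limit of the assay and not a number: the limit of > 100000 nM in this assay, at which 1 of the 4 values shown sits. Chloro in place of hydrogen, ortho to a large group and para to a chloro group, gives an at least 1.8-fold higher number from compound 2 to compound 4 (0.26 log units; that floor lies within the scatter). The other comparisons give an at least 1.5-fold higher number from compound 3 to compound 4 (0.17 log units; that floor lies within the scatter) and an at least 1.3-fold higher number from compound 1 to compound 4 (0.12 log units; that floor lies within the scatter); each is only a floor, so 2,5-dichlorophenyl is the first group here to reach the limit, yet no step is shown beyond the scatter.

As far as these compounds go, how far compound 4 truly lies from the other compounds remains open. So does what an amine or a methoxy group would do at this place on the ring.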